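The source may report more compounds than this note shows. Statements on the series, on what has been measured and on what is new or still open speak of the compounds shown alone.

Measured compounds:
- Compound 1 `Cc1ccc2c(c1)C1(C(=O)N2Cc2ccccc2)C(C#N)=C(N)Oc2cc3oc(-c4ccccc4)cc(=O)c3c(O)c21`: in a functional assay on K562 cells (Homo sapiens) for antiproliferative activity, read by MTT assay, with a stated time of 48 h (on this read-out higher numbers stand for weaker inhibition and lower numbers for stronger inhibition), compound 1 gives > 50000 nM, a limit of the assay rather than a number.
- Compound 2 `COc1ccc2c(c1)C1(C(=O)N2Cc2ccccc2)C(C#N)=C(N)Oc2cc3oc(-c4ccccc4)cc(=O)c3c(O)c21`: in this assay compound 2 gives > 50000 nM, again a limit.
- Compound 3 `N#CC1=C(N)Oc2cc3oc(-c4ccccc4)cc(=O)c3c(O)c2C12C(=O)N(Cc1ccccc1)c1ccc(Cl)cc12`: in this assay compound 3 gives 36300 nM.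

On these data alone, compound 1 therefore stands at the limit of > 50000 nM in this assay, at which 2 of the 3 values shown sit, so its true potency is unknown beyond being weak. The measured steps all change a single substituent on one aromatic ring of the shared core: a step that the two limits leave unreadable from compound 1 to compound 2; an at least 1.3-fold lower number from compound 1 to compound 3 (0.13 log units; that floor lies within the scatter); an at least 1.3-fold lower number from compound 2 to compound 3 (0.13 log units; that floor lies within the scatter). None of them is readable as a clear shift, and none touches the part of the molecule that changes on the way to compound 4 `Cc1ccc2c(c1)C1(C(=O)N2)C(C#N)=C(N)Oc2cc3oc(-c4ccccc4)cc(=O)c3c(O)c21`. That change is hydrogen in place of benzyl on an amide-type nitrogen in a ring. Within the data shown here, no measured step bears on removing this benzyl group, so there is no basis in these data for expecting a step beyond the scatter in this assay in either direction, and the starting point is itself only a limit. Compound 4 is therefore expected to sit near the same limit, with a number no higher from compound 1 to compound 4 (the limit leaves the size open) as the estimated step. The estimate for compound 4 is 50000 nM, with a range from 15000 nM to 150000 nM.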

Compound 4, half-maximal inhibitory concentration: > 50000 nM
Compound 4: no number, only a limit; the forecaster's own chance of this, stated with the estimate: 65%; the middle value lies on the limit itself.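

No step can be read from compound 1 to compound 4 in this assay, because both results are limits rather than numbers: the limit of > 50000 nM in this assay, at which 3 of the 4 values shown sit. The compounds shown leave open whether hydrogen in place of benzyl on the amide-type nitrogen in a ring changes the antiproliferative activity at all, and in which direction.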